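Swapping dimethylamino for diethylamino in compound 4

This account rests on a few compounds, and the source may have more. Where it says the series, first, only, none or still open, it means among the compounds named here.

compound 1 `CCN(CC)CCn1c(N)c(-c2nc3ccccc3[nH]2)c2nc(C#N)c(C#N)nc21` gives 2490 nM
compound 2 `CCN(CC)CCn1c(N)c(-c2nc3ccccc3n2C)c2nc(C#N)c(C#N)nc21` gives > 50000 nM (a limit, not a number)
compound 3 `CN(C)CCn1c(N)c(-c2nc3cc(Cl)ccc3[nH]2)c2nc(C#N)c(C#N)nc21` gives 11300 nM
compound 4 `CCN(CC)CCn1c(N)c(-c2nc3cc(Cl)ccc3[nH]2)c2nc(C#N)c(C#N)nc21` is not yet measured

All of these values come from a functional assay on K562 cells (Homo sapiens) for antiproliferative activity, read by MTT assay, with a stated time of 48 h; a lower number here means a stronger inhibitor, a higher number a weaker inhibitor. Of the two true numbers, the higher belongs to compound 3 at 11300 nM. Compound 1 lies lower at 2490 nM, a gap beyond the scatter, but the two differ in more than one place. The reading for compound 2 is only a limit of the assay (> 50000 nM).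

Compound 4 differs from compound 3 in one place (diethylamino in place of dimethylamino on a saturated chain carbon, two bonds along the chain from an aromatic nitrogen), with diethylamino in place of dimethylamino on a saturated chain carbon, two bonds along the chain from an aromatic nitrogen. Going by the values given here, the only measured single-place step is an at least 20-fold higher number from compound 1 to compound 2 (1.30 log units; beyond the scatter) and it is large, but it is methyl in place of hydrogen on an aromatic nitrogen, a different change that gives no direct measure for this one. The closest guide is compound 1 at 2490 nM, which also carries diethylamino. In this assay a modest move toward a lower number is therefore expected, perhaps none beyond the scatter. The expected change is a 1.9-fold lower number from compound 3 to compound 4 (0.27 log units; within the scatter) in size. For compound 4 the estimate is 6000 nM, with an expected range from 2000 nM to 18000 nM.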

Compound 4, half-maximal inhibitory concentration: > 50000 nM
Compound 4: no number, only a limit (the forecaster's own chance of this, stated with the estimate: 3%); middle value at least 8.3-fold (0.92 log units) away from the limit.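

In this assay compound 4 reads > 50000 nM, which is a limit of the assay and not a number. Going by these compounds alone, with the chloro group kept, diethylamino in place of dimethylamino on a saturated chain carbon, two bonds along the chain from an aromatic nitrogen, gives an at least 4.4-fold higher number from compound 3 to compound 4 (0.64 log units; beyond the scatter), the first measure of a change at this place on the chain. With diethylamino kept, chloro in place of hydrogen on an aromatic carbon gives an at least 20-fold higher number from compound 1 to compound 4 (1.30 log units; beyond the scatter), so both single changes that lead to compound 4 cost activity beyond the scatter, something the earlier step, methyl in place of hydrogen on an aromatic nitrogen, could not show.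

The step between compound 2 and compound 4 joins two limits and cannot be read, and the full size of the other two steps stays unknown, as the readings stop at the top of the range: the limit of > 50000 nM in this assay, at which 2 of the 4 values shown sit. The compounds shown also leave open how a morpholine ring in place of diethylamino, or a fluoro group in place of chloro, would read in this assay.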